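The source may hold more compounds than are shown below. What is called first, only, known or untested is meant among the compounds shown, and "the series" means these compounds.

Measured so far in a physicochemical assay for solubility, in phosphate buffer, with a stated time of 18 h; a lower number here means a less soluble compound, a higher number a more soluble compound
- compound 1 `N#Cc1c(N)nc2nc(C3CC3)ncc2c1N` gives 23000 nM
- compound 2 `N#Cc1c(N)nc2nc(C3CCCC3)ncc2c1N` gives 89000 nM
- compound 3 `CC(C)(C)c1nc(CCCCC#N)c2c(N)c(C#N)c(N)nc2n1` gives 16000 nM

Compound 3 sits with compound 1 at the low end of these three values. The two lie within the scatter of each other, and compound 2 stands clearly higher than either.

The next compound to be read is compound 4 `CC(C)(C)c1nc(-c2ccncc2)c2c(N)c(C#N)c(N)nc2n1`, which carries pyridin-4-yl in place of 4-cyanobutyl on an aromatic carbon and is otherwise unchanged from compound 3.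

For the measured compounds named here, only one measured step is available: a 3.9-fold higher number from compound 1 to compound 2 (0.59 log units; beyond the scatter), for cyclopentyl in place of cyclopropyl on an aromatic carbon. It bears on this change only loosely, since it involves neither of the groups at issue. Going by the values given here, no measured compound carries pyridin-4-yl, and the data do not settle the direction. That modest step serves only as a guide to size. In this assay a small move is expected, tentatively downward and possibly lost in the scatter.

As far as these compounds go, the expected change is a 1.3-fold lower number from compound 3 to compound 4 (0.12 log units; within the scatter), with either direction still open.

For compound 4 the estimated value is 12000 nM, with an expected range from 3500 nM to 45000 nM.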

Compound 4, solubility: 44000 nM
Beside the measured number, compound 4's estimate is 3.7-fold (0.56 log units) below it; the measured number falls inside the stated range.
By their numbers in this assay, from the lowest: compounds 3, 1 and 4 (each within the scatter of the next, the first and the last beyond it); then compound 2.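

In this assay the aromatic carbon next to the ring nitrogen now gives its first read-out of a substituent change with the tert-butyl group held fixed, and the result is a 2.8-fold higher number from compound 3 to compound 4 (0.44 log units; beyond the scatter) for pyridin-4-yl in place of 4-cyanobutyl. The two groups have the same counts of heavy atoms, carbon, nitrogen, hydrogen-bond donors and hydrogen-bond acceptors and differ in form, one an open chain with a triple bond and the other a six-membered aromatic ring, so a step beyond the scatter is seen here with those counts unchanged. No measurement among the data on hand explains this step.

Whether the step belongs to pyridin-4-yl specifically or would also appear with other aromatic rings on this carbon remains open, since neither phenyl nor pyridin-3-yl is among the compounds shown. Also open, as far as these compounds go, are the reading for a longer chain or a simple amine on the same carbon, and whether the step would hold with cyclopentyl or cyclopropyl in place of the tert-butyl group.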